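Ethynyl entering at the aryl-nitrogen methyl: series notes

The source may hold more compounds than are shown below. What is called first, only, known or untested is meant among the compounds shown, and "the series" means these compounds.

Three compounds are measured. In a functional assay for inhibition, with Mus musculus as the target (on this read-out higher numbers stand for weaker inhibition and lower numbers for stronger inhibition), compound 1 `Cc1nc(O)c2cc(CN(C)c3ccc(C(=O)N[C@@H](CCC(=O)O)C(=O)N(C)[C@@H](CCC(=O)O)C(=O)O)c(F)c3)ccc2n1` gives 5100 nM. Compound 3 `Cc1nc(O)c2cc(CN(C)c3ccc(C(=O)N[C@@H](CCC(=O)O)C(=O)N(C)[C@@H](CCC(=O)O)C(=O)O)cc3)c(C)cc2n1` gives 4200 nM in this assay, and compound 2 `C#CCN(Cc1cc2c(O)nc(C)nc2cc1C)c1ccc(C(=O)N[C@@H](CCC(=O)O)C(=O)N(C)[C@@H](CCC(=O)O)C(=O)O)cc1` gives 5000 nM. All three numbers lie within the usual scatter of one another, so no order among them is claimed.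

For the measured compounds named here, the one single-point change that is measured is ethynyl in place of hydrogen on a saturated chain carbon bound to a nitrogen on an aromatic ring, and its step is a 1.2-fold higher number from compound 3 to compound 2 (0.08 log units; within the scatter), within the scatter. Compound 1 and compound 3 differ in more than one place; the difference between the two cores is not broken down here.

Compound 4 `C#CCN(Cc1ccc2nc(C)nc(O)c2c1)c1ccc(C(=O)N[C@@H](CCC(=O)O)C(=O)N(C)[C@@H](CCC(=O)O)C(=O)O)c(F)c1` is not yet measured. Going by the values given here, it differs from compound 1 by ethynyl in place of hydrogen on a saturated chain carbon bound to a nitrogen on an aromatic ring, the same change as the one made from compound 3 to compound 2. The expectation for compound 4 rests on that single measured step, a 1.2-fold higher number from compound 3 to compound 2 (0.08 log units; within the scatter), which stayed within the scatter, and on the value of compound 1, 5100 nM. The step from compound 1 to compound 4 is therefore expected to be small, a 1.1-fold higher number from compound 1 to compound 4 (0.04 log units; within the scatter). Compound 4 is estimated at 5600 nM, with a likely range from 2800 nM to 11000 nM.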

Compound 4, half-maximal inhibitory concentration: 1800 nM
Compound 4: the middle estimate sits 3.1-fold (0.49 log units) above what was measured, and the stated range ends above it.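

In this assay, methyl to propargyl gives a 2.8-fold lower number from compound 1 to compound 4 (0.45 log units; beyond the scatter), so on this core the change goes with stronger inhibition, a modest step. The same change does not carry over at the same size between the two cores: the same change on two cores in this assay, a 1.2-fold higher number (0.08 log units; within the scatter) from compound 3 to compound 2 and a 2.8-fold lower number (0.45 log units; beyond the scatter) from compound 1 to compound 4, 3.4-fold (0.53 log units) apart, beyond the scatter of two such steps. This shows that a step read on one core is a poor guide to the step on the other in this series; with one pair per core, it does not show which of the several differences between the cores goes with the gap, nor whether either step would hold on a third core.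

On these data alone, whether a propyl or an allyl chain at the same place would give a step like that on either core stays open, so the part of the triple bond cannot be told from the part of the longer chain. Also open, as far as these compounds go, is whether a still longer chain, such as butynyl, would follow the step seen on the core of compound 1.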